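The source may hold more compounds than are shown below. What is called first, only, known or untested is meant among the compounds shown, and "the series" means these compounds.

In a functional assay on M21 cells (Homo sapiens) for antiproliferative activity, read by sulforhodamine B assay, with a stated time of 48 h (a lower number here means a stronger inhibitor, a higher number a weaker inhibitor), three compounds sharing one core have been measured. Compound 1 `CN1CCN(c2ccc(S(=O)(=O)Oc3cc(Cl)c(Cl)cc3Cl)cc2)C1=O` gives 420 nM, compound 3 `COc1cc(OC)cc(OS(=O)(=O)c2ccc(N3CCN(C)C3=O)cc2)c1` gives 82 nM, and compound 2 `COc1cccc(OS(=O)(=O)c2ccc(N3CCN(C)C3=O)cc2)c1` gives 1600 nM, the highest number of the three and so the weakest inhibitor among them. Compound 4 `COc1ccc(OS(=O)(=O)c2ccc(N3CCN(C)C3=O)cc2)cc1` is still unmeasured. It has 4-methoxyphenyl in place of the 3-methoxyphenyl of compound 2, on an oxygen: 4-methoxyphenyl in place of 3-methoxyphenyl on an oxygen. Among the compounds with values here, only one measured step bears on this change, methoxy in place of hydrogen on an aromatic carbon, and it was large: a 20-fold lower number from compound 2 to compound 3 (1.29 log units; beyond the scatter). That step shows that a methoxy group can matter greatly in this series, but it adds a group, whereas here the atoms stay the same and are only joined differently. Within the data shown here, no measured pair shows such a change, so a step of that size is not expected, and the direction remains uncertain. The expected step, leaning slightly toward a lower number, is a 1.6-fold lower number from compound 2 to compound 4 (0.20 log units; within the scatter). For compound 4 the estimated value in this assay is 1000 nM, with an expected range from 250 nM to 3500 nM.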

Compound 4, half-maximal inhibitory concentration: > 100000 nM
Compound 4 ended at the assay's limit; the forecaster's own chance of this, stated with the estimate: 5%; at least 100-fold (2.00 log units) between middle value and limit.
By their numbers in this assay, from the lowest: compound 3; then compound 1; then compound 2. At a limit, above all of these: compound 4.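

In this assay compound 4 gives > 100000 nM, which is a limit of the assay and not a number: the limit of > 100000 nM in this assay, at which 1 of the 4 values shown sits.

Even so, the step can be read as a minimum: 4-methoxyphenyl in place of 3-methoxyphenyl on an oxygen gives an at least 62-fold higher number from compound 2 to compound 4 (1.79 log units; beyond the scatter). Within the data shown here, the earlier step showed only that adding a methoxy group can matter greatly, whereas this one shows that, with the same atoms joined differently, 3-methoxyphenyl and 4-methoxyphenyl are far from interchangeable on this oxygen.

The compounds shown leave open whether this loss is specific to the methoxy group or would also follow from an ethoxy group or an amine in its place on the ring. Also open, going by these compounds, is how a plain phenyl ring on this oxygen would compare with compound 2 and compound 4.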